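The compounds below may be only part of what the source reports. "The series", "measured", "known", "first", "only" and "open" are said of these compounds alone.

Measured compounds in an assay on HEK293 cells for displacement of a labelled ligand from 5-hydroxytryptamine receptor 7 (Rattus norvegicus), read by radioligand binding; on this read-out higher numbers stand for weaker inhibition and lower numbers for stronger inhibition:
compound 1 `CC(C)n1nc2c(c1-c1ccccc1)CCNCC2`: 28 nM
compound 2 `CC(C)(C)n1nc2c(c1-c1ccccc1)CCNCC2`: 30 nM
compound 3 `c1ccc(-c2c3c(nn2C2CC2)CCNCC3)cc1`: 20 nM

Compound 1 holds the second highest of the three numbers in this assay, with compound 2 nearest and compound 3 furthest; a 1.1-fold higher number from compound 1 to compound 2 (0.03 log units; within the scatter) and a 1.4-fold lower number from compound 1 to compound 3 (0.15 log units; within the scatter), both within the scatter, and a 1.5-fold lower number from compound 2 to compound 3 (0.18 log units; within the scatter) also within the scatter. All three measured steps change only the group on the aromatic nitrogen of the shared core, and none of them moves the number beyond the scatter.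

Compound 4 `CC(C)n1nc2c(c1-c1ccc(C#N)cc1)CCNCC2` is not yet measured. It differs from compound 1 at a different place: cyano in place of hydrogen on an aromatic carbon. For the measured compounds named here, no measured step touches this ring, so the series gives no direct guide to the size or direction of the change in this assay. With every measured step in this assay within the scatter, no step beyond the scatter is expected here either, and no change at the digits printed from compound 1 to compound 4 (within the scatter) is the estimate for the step. Compound 4 is estimated at 28 nM, with a range from 8 nM to 100 nM.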

Compound 4, inhibition constant: 90 nM
The estimate for compound 4 lay 3.2-fold (0.51 log units) below the measured number, within the range that was stated.
By their numbers in this assay, from the lowest: compounds 3, 1 and 2 (each within the scatter of the next); then compound 4.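

In this assay, for the compounds shown here, cyano in place of hydrogen on an aromatic carbon, para to a large group, gives a 3.2-fold higher number from compound 1 to compound 4 (0.51 log units; beyond the scatter) and is the first step beyond the scatter. The number therefore responds to a change at this place on the six-membered aromatic ring, whereas the three exchanges on the aromatic nitrogen all stayed within the scatter. The change runs toward weaker inhibition and is modest in size, and no measurement at hand accounts for it.

On these data alone, with a single group at this place, it remains open whether the higher number belongs to cyano itself or would also follow an amine, a methoxy group or a fluorine atom there. As far as these compounds go, it is also open whether cyano gives a step of like size when cyclopropyl or tert-butyl sits on the aromatic nitrogen.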